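A Halogen Swap Carried Over to a Second Core

The source may report more compounds than this note shows. Statements on the series, on what has been measured and on what is new or still open speak of the compounds shown alone.

Measured in an assay for inhibition of Alpha amylase (Homo sapiens), with a stated time of 10 min; on this read-out higher numbers stand for weaker inhibition and lower numbers for stronger inhibition:
- compound 1, `COc1cc(Br)c(-c2nc3cc(F)ccc3[nH]2)cc1OC`, gives 1570 nM
- compound 2, `Oc1c(Br)cc(Cl)cc1-c1nc2cc(F)ccc2[nH]1`, gives 2860 nM
- compound 3, `COc1cc(Br)c(-c2nc3cc(Cl)ccc3[nH]2)cc1OC`, gives 1730 nM

Compounds 1 and 3 share one core, and compound 2 carries another; the difference between the two cores is not broken down here. Compound 2 has the highest of the three numbers, but its gaps to compound 3 and to compound 1 are both within the scatter, so the three cannot be ranked.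

Compound 1 and compound 3 differ only by chloro in place of fluoro on an aromatic carbon, and that change gave a 1.1-fold higher number from compound 1 to compound 3 (0.04 log units; within the scatter). Compound 4, `Oc1c(Br)cc(Cl)cc1-c1nc2cc(Cl)ccc2[nH]1`, has not yet been measured. It relates to compound 2 exactly as compound 3 relates to compound 1: the same change, (chloro in place of fluoro on an aromatic carbon), at the same place, now made on the core of compound 2. Going by the values given here, because the one measured instance of this change gave a 1.1-fold higher number from compound 1 to compound 3 (0.04 log units; within the scatter), compound 4 is expected to stay close to its parent, with an expected step of a 1.0-fold higher number from compound 2 to compound 4 (0.02 log units; within the scatter). Compound 4 is therefore estimated at 3000 nM, between 1500 nM and 6000 nM.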

Compound 4, half-maximal inhibitory concentration: 2860 nM
The estimate for compound 4 lay 1.0-fold (0.02 log units) above the measured number, within the range that was stated.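

In this assay, chloro in place of fluoro on the core of compound 2 gave no change at the digits printed from compound 2 to compound 4 (within the scatter), so this change made no visible difference on this core. On the evidence of these two pairs, the change carries from one core to the other without a detectable difference between them: the same change on two cores in this assay, a 1.1-fold higher number (0.04 log units; within the scatter) from compound 1 to compound 3 and no change at the digits printed (within the scatter) from compound 2 to compound 4, 1.1-fold (0.04 log units) apart, within the scatter of two such steps. Going by these compounds alone, this shows only that the swap makes no measurable difference on these two cores. With just two pairs, neither step beyond the scatter, it cannot show that the same would hold on a third core.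

The compounds shown carry only fluoro or chloro at this place on the fused ring system, so it remains open whether a different kind of group there, such as an amine or a carboxylic acid, would move the number beyond the scatter. Also open, going by these compounds, is how each of the differences between the two cores, taken alone, affects the inhibition of the enzyme.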